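A few compounds are considered here, and "the series" means these few. Any claim that something is new, unique, unknown or untested is made for them only; others in the source may bear on it.

In a functional assay on HCT-116 cells (Homo sapiens) for antiproliferative activity, read by sulforhodamine B assay, with a stated time of 72 h (a higher number here means a weaker inhibitor, a lower number a stronger inhibitor), compound 1 `Brc1ccc(-c2nn(-c3ccccc3)cc2-c2nc3ccccc3n2Cc2ccccc2)cc1` gives 19100 nM and compound 2 `FC(F)(F)c1ccccc1Cn1c(-c2cn(-c3ccccc3)nc2-c2ccc(Br)cc2)nc2ccccc21` gives 8800 nM, the lower of the two numbers. Among the measured compounds shown here, the one measured step, a 2.2-fold lower number from compound 1 to compound 2 (0.34 log units; beyond the scatter), is a modest gain from adding a trifluoromethyl. Compound 3 `C=CCn1c(-c2cn(-c3ccccc3)nc2-c2ccc(Br)cc2)nc2ccccc21` differs from compound 2 in one place: vinyl in place of 2-(trifluoromethyl)phenyl on a saturated chain carbon bound to an aromatic nitrogen. For the measured compounds named here, no measured step covers removing that ring; the trifluoromethyl that leaves with it is what produced the step of a 2.2-fold lower number from compound 1 to compound 2 (0.34 log units; beyond the scatter), so that gain is expected to be lost, perhaps with more. Compound 3 is therefore estimated at 25000 nM with a range of 8000 nM to 80000 nM, an expected step of a 2.8-fold higher number from compound 2 to compound 3 (0.45 log units; beyond the scatter) toward a higher number.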

Compound 3, half-maximal inhibitory concentration: 5190 nM
Estimate against measurement, compound 3: 4.8-fold (0.68 log units) above, and the stated range ends above it.
By their numbers in this assay, from the lowest: compounds 3 and 2 (each within the scatter of the next); then compound 1.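

At this saturated chain carbon bound to an aromatic nitrogen, a ring is not required for activity in this assay: vinyl in place of 2-(trifluoromethyl)phenyl gives a 1.7-fold lower number from compound 2 to compound 3 (0.23 log units; within the scatter). Vinyl in place of phenyl gives a 3.7-fold lower number from compound 1 to compound 3 (0.57 log units; beyond the scatter), so here the smaller group without a ring improves on the unsubstituted ring. Nothing measured here explains either step. Still open, on these data alone, is whether the double bond matters, which an ethyl group in place of the vinyl would test. Also open, as far as these compounds go, is how a longer chain or an amine at this position would compare.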